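A few compounds are considered here, and "the series" means these few. Any claim that something is new, unique, unknown or untested is made for them only; others in the source may bear on it.

Compound 2 `CC(=O)c1c(NNc2ccc(C)cc2)cc(C)oc1=O` stands highest of the two numbers in a functional assay on the whole organism (strain Swiss albino) with Mus musculus as the target, with stated times of 30 min and 10 min, at a dose of 50 mg/kg by the oral route (on this read-out lower numbers stand for less inhibition and higher numbers for more inhibition at the one dose given (going by the name of the read-out)), where compound 2 gives 70.2%; compound 1 `CC(=O)c1c(NNc2ccccc2)cc(C)oc1=O` gives 49.8%. For the measured compounds named here, the one measured step, a number 20.4 percentage points higher from compound 1 to compound 2 (beyond the scatter), concerns methyl in place of hydrogen and does not cover the change leading to compound 3 `CC(=O)c1c(NNc2ccc(Cl)cc2)cc(C)oc1=O`, which is chloro in place of methyl on an aromatic carbon. Going by the values given here, no measured step bears directly on chloro in place of methyl, so no step beyond the scatter is expected, a number 5.2 percentage points lower from compound 2 to compound 3 (within the scatter). Compound 3 is estimated at 65%, with an expected range from 45% to 85%.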

Compound 3, a percentage reported as inhibition, in the whole organism at one dose (the size of the read-out at that dose, not a potency): 75.1%
Estimate against measurement, compound 3: 10.1 percentage points below; the range from low to high includes it.
By their numbers in this assay, from the lowest: compound 1; then compounds 2 and 3 (each within the scatter of the next).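

On an aromatic carbon para to a large group, chloro in place of methyl gives a number 4.9 percentage points higher from compound 2 to compound 3 (within the scatter) in this assay and so does not separate the two groups at this place. Chloro in place of hydrogen gives a number 25.3 percentage points higher from compound 1 to compound 3 (beyond the scatter) in the same read-out, so with compound 2 and compound 3 two different groups at this place now stand beyond the scatter from hydrogen in compound 1. Nothing available explains these differences.

Open, going by these compounds, is whether a methoxy group, an amine or a carboxylic acid at this place would hold the read-out of compound 3. Also open, on these data alone, is whether chloro elsewhere on the same ring would do the same.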